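The source may report more compounds than this note shows. Statements on the series, on what has been measured and on what is new or still open speak of the compounds shown alone.

Measured in a functional assay on MCF7 cells (Homo sapiens) for inhibition; a lower number here means a stronger inhibitor, a higher number a weaker inhibitor:
compound 1, `c1ccc(Nc2cccc(-c3nc4ccccc4s3)c2)nc1`, gives 13000 nM
compound 2, `CCn1c(=O)/c(=C2\Sc3ccc(C)cc3N2C)s/c1=C\c1ccncc1Nc1ccccc1Cl`, gives 650 nM

Compound 2 holds the lower of the two numbers in this assay; compound 1 stands far above it, well beyond the scatter. Compound 3, `CCn1c(=O)/c(=C2\Sc3ccc(OC)cc3N2C)s/c1=C\c1ccncc1Nc1ccccc1Cl`, has not yet been measured. It differs from compound 2 in one respect only: methoxy in place of methyl on an aromatic carbon. Going by the values given here, no measured pair shows this particular change, so nothing in the data sets its size. The step of a 1.1-fold lower number from compound 2 to compound 3 (0.03 log units; within the scatter) is expected to stay within the scatter, in no definite direction. Compound 3 is therefore estimated at 600 nM, with a range from 250 nM to 1500 nM.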

Compound 3, half-maximal inhibitory concentration: 710 nM
Compound 3: the middle estimate sits 1.2-fold (0.07 log units) below what was measured, and the stated range covers the measured number.
By their numbers in this assay, from the lowest: compounds 2 and 3 (each within the scatter of the next); then compound 1.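

In this assay, going by these compounds alone, methoxy in place of methyl on this aromatic carbon gives a 1.1-fold higher number from compound 2 to compound 3 (0.04 log units; within the scatter), the first reading of any change at this position. The step adds a heavy atom and a hydrogen-bond acceptor, yet the assay does not separate the two groups, so methyl and methoxy are equivalent here within the scatter. Nothing available explains this result. On these data alone, whether an amine, a carboxylic acid or a longer alkoxy chain on the same carbon would move the number beyond the scatter remains open.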